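Hydrogen for nitro on compound 2

This account rests on a few compounds, and the source may have more. Where it says the series, first, only, none or still open, it means among the compounds named here.

In a functional assay on DU-145 cells (Homo sapiens) for inhibition, read by trypan blue exclusion, with a stated time of 96 h (on this read-out lower numbers stand for stronger inhibition of growth and higher numbers for weaker inhibition of growth), compound 1 (`Nc1c(Br)cc(Br)cc1/C=C(/Sc1ccc(Br)cc1)C(=O)c1ccc(Br)cc1`) gives > 100000 nM as a limit only. Among the compounds with values here, compound 2 (`O=C(/C(=C\c1ccc(Cl)c([N+](=O)[O-])c1)Sc1ccc(Br)cc1)c1ccc(Br)cc1`) gives 10000 nM as the only actual number so far. Compound 3 (`O=C(/C(=C\c1ccc(Cl)cc1)Sc1ccc(Br)cc1)c1ccc(Br)cc1`) carries hydrogen in place of nitro on an aromatic carbon, ortho to a chloro group (hydrogen in place of nitro on an aromatic carbon). Within the data shown here, no measured step covers this change, so in this assay only a small loss of growth inhibition is expected, not far beyond the scatter. The estimate puts the expected step (a 1.5-fold higher number from compound 2 to compound 3 (0.18 log units; within the scatter)) in that direction. For compound 3 the estimated value is 15000 nM with an expected range (4000 nM to 60000 nM).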

Compound 3, concentration for 50% growth inhibition: 1000 nM
For compound 3 the middle estimate is 15-fold (1.18 log units) above the measured one, outside the stated range (below it).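

In this assay hydrogen in place of nitro, ortho to a chloro group, improves growth inhibition (a 10-fold lower number from compound 2 to compound 3 (1.00 log units; beyond the scatter)), so nitro is not needed at this position in this pair. The change of 4-chlorophenyl for 2-amino-3,5-dibromophenyl spans a wider gap (an at least 100-fold lower number from compound 1 to compound 3 (2.00 log units; beyond the scatter)). Compound 1 stands only as a limit: the limit of > 100000 nM in this assay, at which 1 of the 3 values shown sits.

Open, on these data alone, is whether fluoro, methoxy or an amine at this position would match hydrogen. Also open is which of the amino and bromo groups of compound 1 accounts for its step.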